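A Fluoro-to-Methyl Swap on Compound 2

This account rests on a few compounds, and the source may have more. Where it says the series, first, only, none or still open, it means among the compounds named here.

Three compounds have been measured in a functional assay on CCRF-CEM cells (Homo sapiens) for antiproliferative activity, read by MTT assay, with a stated time of 72 h, tested at 25 uM; on this read-out higher numbers stand for a weaker effect at the one concentration tested and lower numbers for a stronger effect:

compound 1, `COC(C(=O)OC(C)Cn1cnc2c1c(=O)n(C)c(=O)n2C)c1cccc2ccccc12`: 96.6%
compound 2, `CC(Cn1cnc2c1c(=O)n(C)c(=O)n2C)OC(=O)CC(=O)c1ccc(F)cc1`: 83.5%
compound 3, `CC(Cn1cnc2c1c(=O)n(C)c(=O)n2C)OC(=O)Sc1ccccc1`: 53.9%

Among these three numbers compound 2 stands second highest. Its nearest neighbour is compound 1, whose number is higher by a gap that lies beyond the usual scatter, while compound 3 sits furthest away with a number lower by a gap that also lies beyond the scatter. Going by the values given here, no pair of these measured compounds differs in a single place, so no measured step can be read from them.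

The compound that has not yet been measured is compound 4, `Cc1ccc(C(=O)CC(=O)OC(C)Cn2cnc3c2c(=O)n(C)c(=O)n3C)cc1`. It differs from compound 2 only in the group on the six-membered aromatic ring of carbon only, para to the large group: methyl in place of fluoro on an aromatic carbon. Among the compounds with values here, with no measured step of this kind to draw on, the step is expected to stay small, in either direction or none beyond the scatter, and compound 2 with 83.5% is taken as the anchor.

The expected step in this assay from compound 2 to compound 4 is therefore a number 3.5 percentage points lower from compound 2 to compound 4 (within the scatter). For compound 4 the estimated value is 80%, in a range from 62% to 95%.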

Compound 4, a percentage reported as activity, at one concentration (the size of the read-out at that concentration, not a potency): 89.5%
Compound 4: the middle estimate sits 9.5 percentage points below what was measured; the measured number falls inside the stated range.
By their numbers in this assay, from the lowest: compound 3; then compounds 2, 4 and 1 (each within the scatter of the next, the first and the last beyond it).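

In this assay, going by these compounds alone, the replacement of fluoro by methyl on an aromatic carbon, para to a large group, provides the first step in this set that can be read at a single place: a number 6 percentage points higher from compound 2 to compound 4 (within the scatter). The earlier compounds shown here could not show this, and it means that going from 4-fluorophenyl to 4-methylphenyl leaves the read-out at the one tested concentration within the usual scatter, so this one swap gives no sign of a real change at this position. No measurement is available that bears on this result or could account for it.

What the compounds shown leave open is whether another group at this same position, such as an amine, a carboxylic acid or a longer alkyl chain, would produce a step beyond the scatter. On these data alone, the remaining pairs differ in more than one place, so their steps cannot be read, and it also stays open whether this swap would give a similar step in a compound with a different ester portion.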